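Extending the Chain of an Amino Alcohol Growth Inhibitor

The source may hold more compounds than are shown below. What is called first, only, known or untested is meant among the compounds shown, and "the series" means these compounds.

Measured compounds:
- compound 1, `CCCCCCCCCCCCCCC[C@@H](O)[C@@H](N)[C@@H](C)O`, 19000 nM
- compound 2, `CCCCCCCCCCCCCCC[C@@H](O)[C@@H](N)C(C)C`, 21000 nM
- compound 3, `CCCCCCCCC[C@@H](O)[C@H](C)N`, 9200 nM

In a functional assay on HeLa cells (Homo sapiens) for antiproliferative activity, read by sulforhodamine B assay, with a stated time of 48 h (a lower number here means a stronger inhibitor of growth, a higher number a weaker inhibitor of growth), compound 3 gives the lowest number of the three, and its gaps to compound 1 and compound 2 both lie beyond the usual scatter. Compound 4, `CCCCCCCCCCCCCCC[C@@H](O)[C@H](C)N`, differs from compound 3 in one place: hexyl in place of hydrogen on a saturated chain carbon, ten or more bonds along the chain from an oxygen on a saturated carbon. Among the measured compounds shown here, the only measured step, a 1.1-fold higher number from compound 1 to compound 2 (0.04 log units; within the scatter), concerns another position and says nothing about chain length. Compound 1 and compound 2 carry the longer chain and both give higher numbers than compound 3, yet they also differ elsewhere, so the chain alone cannot be singled out. A modest rise toward their level is therefore expected, a 1.4-fold higher number from compound 3 to compound 4 (0.15 log units; within the scatter). For compound 4 the estimate is 13000 nM, with a range from 5000 nM to 32000 nM.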

Compound 4, concentration for 50% growth inhibition: 2600 nM
Compound 4: the middle estimate sits 5.0-fold (0.70 log units) above what was measured; the measured number lies below the stated range.
By their numbers in this assay, from the lowest: compound 4; then compound 3; then compounds 1 and 2 (each within the scatter of the next).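

In this assay, hexyl in place of hydrogen on a saturated chain carbon, ten or more bonds along the chain from an oxygen on a saturated carbon, gives a 3.5-fold lower number from compound 3 to compound 4 (0.55 log units; beyond the scatter) and so links the longer chain to stronger growth inhibition. With that chain kept, the carbon bound to an amine nitrogen and a saturated chain carbon also matters: methyl in place of isopropyl gives an 8.1-fold lower number from compound 2 to compound 4 (0.91 log units; beyond the scatter) and methyl in place of 1-hydroxyethyl gives a 7.3-fold lower number from compound 1 to compound 4 (0.86 log units; beyond the scatter) as well. From the compounds shown here alone, whether a still longer chain, or an ethyl group in place of that methyl, would lower the number further stays open. Nothing shown here explains why these steps occur.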